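A few compounds are considered here, and "the series" means these few. Any claim that something is new, unique, unknown or untested is made for them only; others in the source may bear on it.

Measured compounds:
compound 1, `Cc1ccc(Cl)cc1-n1nncc1CN1C(=O)C2(C(C#N)=C(N)Oc3c2c2nc4ccccc4nc2c2ccccc32)c2ccccc21`: > 50000 nM
compound 2, `CCc1ccccc1-n1nncc1CN1C(=O)C2(C(C#N)=C(N)Oc3c(N)cc4nc5ccccc5nc4c32)c2ccccc21`: 17900 nM

In a functional assay on HepG2 cells (Homo sapiens) for antiproliferative activity, read by MTT assay, with a stated time of 48 h (a higher number here means a weaker inhibitor, a lower number a stronger inhibitor), compound 1 returns only a limit, > 50000 nM; this is the limit of > 50000 nM in this assay, at which 1 of the 2 values shown sits. For the measured compounds named here, compound 2 gives 17900 nM in this assay and is thus the only compound with an actual number among the two values shown. Compound 3, `N#CC1=C(N)Oc2c(N)cc3nc4ccccc4nc3c2C12C(=O)N(Cc1cnnn1-c1ccccc1Br)c1ccccc12`, has not yet been measured in this assay. It differs from compound 2 by bromo in place of ethyl on an aromatic carbon. Going by the values given here, no measured pair shows a step of this kind, so for compound 3 no change beyond the usual scatter is expected in either direction. Compound 3 is therefore estimated at 18000 nM, with a range from 7000 nM to 45000 nM. This expectation amounts to a step of a 1.0-fold higher number from compound 2 to compound 3 (0.00 log units; within the scatter).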

Compound 3, half-maximal inhibitory concentration: 38000 nM
Estimate against measurement, compound 3: 2.1-fold (0.32 log units) below; the range from low to high includes it.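

In this assay, changing 2-ethylphenyl to 2-bromophenyl gives a 2.1-fold higher number from compound 2 to compound 3 (0.33 log units; beyond the scatter), so this place on the aromatic carbon, ortho to a large group, does not tolerate every substituent equally. Bromo, with fewer heavy atoms than ethyl, goes with the weaker inhibitor in this one pair. Any further weakening from here would soon meet the limit that compound 1 returns, which is a limit and not a number: the limit of > 50000 nM in this assay, at which 1 of the 3 values shown sits.

The compounds shown leave open whether a methoxy group or an amine at this place would lower the number. One pair also cannot show whether other halogens, such as fluoro or chloro, would follow bromo.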